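The source may hold more compounds than are shown below. What is called first, only, known or untested is meant among the compounds shown, and "the series" means these compounds.

Measured so far in a functional assay on cells (Cancer cell lines, Homo sapiens) for inhibition; a higher number here means a weaker inhibitor of growth, a lower number a stronger inhibitor of growth:
- compound 1 `Cc1cn2c(/C=N/NC(=N)N)c(-c3cccs3)nc2s1`: 7760 nM
- compound 2 `N=C(N)N/N=C/c1c(-c2ccsc2)nc2n1CCS2`: 28800 nM

Compound 2 has the higher number of the pair, which makes it the weaker growth inhibitor, and its gap to compound 1 lies beyond the scatter. Among the compounds with values here, the two compounds differ in more than one place, so no single-change step has been measured yet.

The next compound is compound 3 `N=C(N)N/N=C/c1c(-c2cccs2)nc2n1CCS2`, which has the same atoms as compound 2, joined differently: thiophen-2-yl in place of thiophen-3-yl on an aromatic carbon. Within the data shown here, the only guide to this change is indirect. Compound 1 also carries thiophen-2-yl and gives 7760 nM, but its core differs from that of compound 2, so the gap between them cannot be assigned to the thiophene alone.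

The expected step of a 1.6-fold lower number from compound 2 to compound 3 (0.20 log units; within the scatter) in this assay is small, towards a lower number, and may stay within the scatter. For compound 3 the estimated value is 18000 nM, with an expected range of 7000 nM to 40000 nM.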

Compound 3, concentration for 50% growth inhibition: 28800 nM
Beside the measured number, compound 3's estimate is 1.6-fold (0.20 log units) below it, and the stated range covers the measured number.
By their numbers in this assay, from the lowest: compound 1; then compounds 2 and 3 (each within the scatter of the next).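

In this assay, within the data shown here, thiophen-2-yl in place of thiophen-3-yl on the aromatic carbon of the shared core gives no change at the digits printed from compound 2 to compound 3 (within the scatter) and so provides the first single-change reading. On this core, the point of attachment of the thiophene therefore has no readable effect on growth inhibition, which the earlier pair could not show because compound 1 and compound 2 differ in more than one place. No available data bear on why these two thiophene isomers read alike.

Still open, from the compounds shown here alone, is whether a different group at this position, such as phenyl, pyridin-3-yl or a small amine, would move the number beyond the scatter, or whether this position tolerates changes more broadly. Going by these compounds, it is also open whether the same exchange of thiophene isomers on the core of compound 1 would read alike, so the result cannot yet be carried over from the shared core of compound 2 and compound 3 to that core.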